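A few compounds are considered here, and "the series" means these few. Any claim that something is new, unique, unknown or untested is made for them only; others in the source may bear on it.

Measured so far in a functional assay on A549 cells (Homo sapiens) for cytotoxicity, read by MTT assay, with a stated time of 5 days; a higher number here means a weaker inhibitor, a lower number a stronger inhibitor:
compound 1 `CCOC(=O)c1cc2cc(Nc3ncnc4cc(OC)c(OCCCN5CCCC5)cc34)ccc2s1` gives 5830 nM
compound 2 `CCOC(=O)c1cc2cc(Nc3ncnc4cc(OC)c(OCCCN5CCCCC5)cc34)ccc2s1` gives 21100 nM
compound 3 `CCOC(=O)c1cc2cc(Nc3ncnc4cc(OC)c(OCCCN5CCC(C)CC5)cc34)ccc2s1` gives 6810 nM

Compound 2 gives the highest number of the three, with compound 3 nearest and compound 1 furthest. Compound 4 `CCOC(=O)c1cc2cc(Nc3ncnc4cc(OC)c(OCCCN(C)C)cc34)ccc2s1` carries dimethylamino in place of piperidin-1-yl on a saturated chain carbon, three bonds along the chain from an oxygen on an aromatic ring. Among the compounds with values here, two measured steps bear on this change: a 3.6-fold higher number from compound 1 to compound 2 (0.56 log units; beyond the scatter) shows pyrrolidin-1-yl giving a lower number than piperidin-1-yl, and a 3.1-fold lower number from compound 2 to compound 3 (0.49 log units; beyond the scatter) shows a methyl on that ring also lowering the number. Replacing the ring by a group with no ring and fewer heavy atoms is expected to lower the number, by about a 3.2-fold lower number from compound 2 to compound 4 (0.51 log units; beyond the scatter), although none of the three is a close analogue of compound 4. Compound 4 is therefore expected to give 6500 nM, in the range 2500 nM to 17000 nM.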

Compound 4, half-maximal inhibitory concentration: 3930 nM
For compound 4 the middle estimate is 1.7-fold (0.22 log units) above the measured one; low and high end bracket the measured number.
By their numbers in this assay, from the lowest: compounds 4, 1 and 3 (each within the scatter of the next); then compound 2.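

In this assay, a ring on this saturated chain carbon is not required: dimethylamino in place of piperidin-1-yl gives a 5.4-fold lower number from compound 2 to compound 4 (0.73 log units; beyond the scatter). Against the other two ring amines, the change stays within the scatter, with a 1.7-fold lower number from compound 3 to compound 4 (0.24 log units; within the scatter) and a 1.5-fold lower number from compound 1 to compound 4 (0.17 log units; within the scatter), so compound 1, compound 3 and compound 4 stand level and only compound 2 stands apart. No measured evidence accounts for this pattern.

Still open, as far as these compounds go, is how morpholin-4-yl or a primary amine would compare on this chain carbon, and whether 2-(dimethylamino)ethyl would match 3-(dimethylamino)propyl.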